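Amide group swap from compound 3 to compound 4

The source may report more compounds than this note shows. Statements on the series, on what has been measured and on what is new or still open speak of the compounds shown alone.

Measured so far:
compound 1 `Cc1csc(C(=O)N[C@H]2CN(S(=O)(=O)c3ccccc3)C[C@@H]2C(=O)N[C@H]2CCCNC2)n1` gives 9.1 mL.min-1.g-1
compound 2 `O=C(N[C@H]1CN(S(=O)(=O)c2ccccc2)C[C@@H]1C(=O)N[C@H]1CCCNC1)c1cc(C2CC2)n[nH]1` gives < 3 mL.min-1.g-1 (a limit)
compound 3 `O=C(N[C@H]1CN(S(=O)(=O)c2ccccc2)C[C@@H]1C(=O)N[C@H]1CCCNC1)c1cc(-c2ccccc2)on1` gives < 3 mL.min-1.g-1 (a limit)

In an ADME assay on microsomes from liver (Homo sapiens) for metabolic stability (a higher number here means faster removal of the compound, a lower number slower removal), compound 3 stands at the limit of < 3 mL.min-1.g-1 in this assay, at which 2 of the 3 values shown sit, so its entry is a limit and not a number. The change to compound 4 `O=C(N[C@H]1CN(S(=O)(=O)c2ccccc2)C[C@@H]1C(=O)N[C@H]1CCCNC1)c1nnc(-c2ccc(F)cc2)s1` is a group of 12 heavy atoms (8 carbon, 2 nitrogen, 1 fluorine, 1 sulfur; one five-membered aromatic ring with 3 hetero atoms, one six-membered aromatic ring of carbon only) in place of a group of 11 heavy atoms (9 carbon, 1 nitrogen, 1 oxygen; one five-membered aromatic ring with 2 hetero atoms, one six-membered aromatic ring of carbon only), on a carbonyl carbon, and the rest of the molecule stays the same. Within the data shown here, two measured steps bear on it: an at least 3.0-fold lower number from compound 1 to compound 2 (0.48 log units; beyond the scatter) and an at least 3.0-fold lower number from compound 1 to compound 3 (0.48 log units; beyond the scatter). Going by these compounds, both replace the 4-methyl-1,3-thiazol-2-yl group and both end at the limit, so their full sizes stay open. There is also a step that the two limits leave unreadable from compound 2 to compound 3, which gives no size. Like compound 3, compound 4 holds one five-membered aromatic ring and one six-membered aromatic ring of carbon only, so no step beyond the scatter is expected. The step expected is an at least 1.1-fold higher number from compound 3 to compound 4 (0.06 log units; that floor lies within the scatter), though a report at the limit is also quite possible. Among the measured compounds shown here, the only measured number, from compound 1 at 9.1 mL.min-1.g-1, sets the upper reach of this expectation. For compound 4 the estimated value is 3.5 mL.min-1.g-1, with an expected range from 2 mL.min-1.g-1 to 9 mL.min-1.g-1.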

Compound 4, intrinsic clearance in microsomes in the Homo sapiens assay: 8.8 mL.min-1.g-1
Beside the measured number, compound 4's estimate is 2.5-fold (0.40 log units) below it; low and high end bracket the measured number.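

In the Homo sapiens assay, compound 4 gives 8.8 mL.min-1.g-1, so a five-membered aromatic ring carrying a six-membered aromatic ring does not by itself keep the number low at this position on the carbonyl carbon: the data show an at least 2.9-fold higher number from compound 3 to compound 4 (0.46 log units; beyond the scatter) and an at least 2.9-fold higher number from compound 2 to compound 4 (0.46 log units; beyond the scatter). Both steps are floors, since the values of compounds 2 and 3 are limits and not numbers: the limit of < 3 mL.min-1.g-1 in the Homo sapiens assay, at which 2 of the 4 values shown sit. In the Homo sapiens assay, the much smaller 4-methyl-1,3-thiazol-2-yl group gives a matching result, with a 1.0-fold lower number from compound 1 to compound 4 (0.01 log units; within the scatter). In a physicochemical assay for lipophilicity, measured as octanol-water partition, at pH 7.4 (on this read-out higher numbers stand for higher lipophilicity and lower numbers for lower lipophilicity), compound 3 gives 1.3 and compound 4 gives 1, and the swap shows a number 0.30 log units lower from compound 3 to compound 4 (within the scatter).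

Going by these compounds, the swap from compound 3 to compound 4 alters the five-membered ring and brings in fluorine together, so which change carries the step stays open. Also open, on these data alone, is how an amine or a carboxylic acid on this group would read in the Homo sapiens assay.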